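Notes on the step from compound 2 to compound 3

The source may report more compounds than this note shows. Statements on the series, on what has been measured and on what is new or still open speak of the compounds shown alone.

Measured in a functional assay on cells (Lymphocyte, Homo sapiens); on this read-out lower numbers stand for stronger inhibition and higher numbers for weaker inhibition:
- compound 1, `Nc1nc(N2CCN(C(=O)COc3ccc(Cl)cc3)CC2)c2nc(CCCCc3ccc(F)cc3)sc2n1`, gives 920 nM
- compound 2, `CCCCCc1nc2c(N3CCN(C(=O)COc4ccc(Cl)cc4)CC3)nc(N)nc2s1`, gives 690 nM

Compound 2 has the lowest of the two numbers shown, but the only measured step, a 1.3-fold lower number from compound 1 to compound 2 (0.12 log units; within the scatter), is within the scatter, so no order between compound 2 and compound 1 can be read from these two values.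

Compound 3, `Nc1nc(N2CCN(C(=O)COc3ccc(Cl)cc3)CC2)c2nc(-c3ccncc3)sc2n1`, is the next compound in the series. It differs from compound 2 as follows: pyridin-4-yl in place of pentyl on an aromatic carbon.

Going by the values given here, the one measured step swaps a group on a saturated chain carbon, four bonds along the chain from an aromatic carbon, and is within the scatter. Among the compounds with values here, the change to compound 3 sits elsewhere, on an aromatic carbon of the shared core, and replaces the whole pentyl chain with pyridin-4-yl; no measured step tests a change of that kind. The step from compound 1 to compound 2 therefore bears on it only loosely, and it gives no ground to expect a shift beyond the scatter in either direction in this assay.

For compound 3 the expected step is a 1.2-fold higher number from compound 2 to compound 3 (0.06 log units; within the scatter), with a wide range to reflect the lack of a comparable measured step. Compound 3 is thus estimated at 800 nM in this assay, with a range from 250 nM to 3000 nM.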

Compound 3, half-maximal inhibitory concentration: 40 nM
The estimate for compound 3 lay 20-fold (1.30 log units) above the measured number, outside the stated range (below it).
By their numbers in this assay, from the lowest: compound 3; then compounds 2 and 1 (each within the scatter of the next).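

In this assay, the aromatic carbon of the five-membered aromatic ring with 1 nitrogen and 1 sulfur turns out to be a position where the substituent matters, with pyridin-4-yl in place of pentyl giving a 17-fold lower number from compound 2 to compound 3 (1.24 log units; beyond the scatter) and pyridin-4-yl in place of 4-(4-fluorophenyl)butyl giving a 23-fold lower number from compound 1 to compound 3 (1.36 log units; beyond the scatter). The earlier step, a 1.3-fold lower number from compound 1 to compound 2 (0.12 log units; within the scatter), compared only two chains at this carbon and stayed within the scatter, whereas an aromatic ring set directly on the carbon makes compound 3 the strongest inhibitor of the three. No measured evidence is available to explain the size of these steps.

The compounds shown leave open whether the lower number goes with the aromatic ring itself or with its ring nitrogen: phenyl at this carbon would separate the two, and pyridin-3-yl would test where that nitrogen sits. Also open, on these data alone, is how much of the step would survive with the pyridin-4-yl moved out to the end of a butyl chain, the arrangement that compound 1 has with its 4-fluorophenyl.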